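Diol in place of the styryl arm on the shared core

The source may report more compounds than this note shows. Statements on the series, on what has been measured and on what is new or still open speak of the compounds shown alone.

For the measured compounds named here, compound 1 `Nc1nc(O)c2c(n1)n(C1OC(CO)[C@@H](O)[C@H]1O)c(=O)n2C/C=C/c1ccccc1` is the weaker of the two measured members in a functional assay (B cells) with Mus musculus as the target; on this read-out lower numbers stand for an effect already at smaller amounts and higher numbers for an effect only at larger amounts of compound: compound 1 gives 103 uM. Going by the values given here, the only other measured compound, compound 2 `CCCn1c(=O)n(C2OC(COP(=O)(O)O)[C@@H](O)[C@H]2O)c2nc(N)nc(O)c21`, gives 15 uM in this assay, a gap that lies beyond the scatter, but compound 2 differs from compound 1 in more than one place, so no single step can be read from the pair.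

Compound 3 `Nc1nc(O)c2c(n1)n(C1OC(CO)[C@@H](O)[C@H]1O)c(=O)n2CC(O)CO` keeps the core of compound 1 and alters one arm: 1,2-dihydroxyethyl in place of 2-phenylethenyl on a saturated chain carbon bound to an aromatic nitrogen. Among the compounds with values here, no measured pair isolates this change, so nothing in the data sets its size or direction. With no aromatic group left on that arm and two hydrogen-bond donors and two acceptors added, the expectation is a modest loss rather than a gain, with a step of a 1.5-fold higher number from compound 1 to compound 3 (0.16 log units; within the scatter) from compound 1 to compound 3 that may stay within the scatter. Compound 3 is therefore estimated at 150 uM in this assay, expected to fall between 40 uM and 500 uM.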

Compound 3, concentration for half-maximal effect: 45 uM
The estimate for compound 3 lay 3.3-fold (0.52 log units) above the measured number; low and high end bracket the measured number.
By their numbers in this assay, from the lowest: compound 2; then compound 3; then compound 1.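

In this assay, the place on a saturated chain carbon bound to an aromatic nitrogen does not depend on an aromatic group: 1,2-dihydroxyethyl in place of 2-phenylethenyl gives a 2.3-fold lower number from compound 1 to compound 3 (0.36 log units; beyond the scatter). For the compounds shown here, this is the first single change that can be read, and its direction is a modest gain, even though the six-membered aromatic ring and the double bond leave and the hydrogen-bond donors and acceptors of the 1,2-dihydroxyethyl group enter. No measurement bears on what lies behind this step, so the result gives its size and direction only.

Still open, as far as these compounds go, is which part of the exchange carries the step: the phenyl ring, the double bond or the entering hydroxyl groups. A 2-phenylethyl arm at this place would separate the double bond from the ring, while an aminoethyl or carboxymethyl arm, or a longer chain bearing hydroxyl groups, would show whether the hydroxyl groups themselves matter or whether other groups serve equally well.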